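Methoxy for hydrogen on the aryl ring: expected inhibition

A few compounds are considered here, and "the series" means these few. Any claim that something is new, unique, unknown or untested is made for them only; others in the source may bear on it.

Of the compounds shown here, two have been measured. Compound 1 `COc1ccc(-c2nc(C)c(C(=O)CSc3nc(N)c(C#N)c(-c4ccc(Cl)cc4)n3)s2)cc1` gives 1.1% in an assay on membranes from CHO cells for displacement of a labelled ligand from adenosine receptor A1 (Homo sapiens), read by scintillation counting, with a stated time of 60 min, tested at 1 uM; a higher number here means more inhibition at the concentration tested (going by the name of the read-out), a lower number less inhibition. Compound 2 `COc1ccc(-c2nc(C)c(C(=O)CSc3nc(N)c(C#N)c(-c4ccccc4)n3)s2)cc1` gives -2.8% in this assay. For the measured compounds named here, the single step between them, a number 3.9 percentage points lower from compound 1 to compound 2 (within the scatter), lies within the scatter, so compound 2 stands as the lower of the two numbers without any real separation from compound 1; both sit near zero. Compound 3 `COc1ccc(-c2nc(C)c(C(=O)CSc3nc(N)c(C#N)c(-c4ccc(OC)cc4)n3)s2)cc1` differs from compound 2 by methoxy in place of hydrogen on an aromatic carbon. Going by the values given here, no measured step concerns a methoxy group. Among the compounds with values here, the only step available, hydrogen in place of chloro, gave a number 3.9 percentage points lower from compound 1 to compound 2 (within the scatter) and bears on compound 3 only in showing that a change on this aromatic carbon left the read-out near zero. The expected step is therefore a number 2.8 percentage points higher from compound 2 to compound 3 (within the scatter), nothing beyond the scatter. Compound 3 is estimated at 0%, with a range from -10% to 10%.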

Compound 3, a percentage reported as inhibition, at one concentration (the size of the read-out at that concentration, not a potency): 9%
Compound 3: middle estimate off by 9 percentage points, on the low side, within the range that was stated.
By their numbers in this assay, from the lowest: compounds 2, 1 and 3 (each within the scatter of the next, the first and the last beyond it).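

In this assay, for the compounds shown here, the step of a number 11.8 percentage points higher from compound 2 to compound 3 (beyond the scatter) is the first beyond the scatter, so the aromatic carbon para to a large group is not silent: phenyl to 4-methoxyphenyl moves the read-out, though only modestly. The step of a number 7.9 percentage points higher from compound 1 to compound 3 (within the scatter) does not separate methoxy from chloro at this carbon, so only methoxy against hydrogen stands apart, and the read-out stays a small one at a single concentration. Nothing at hand bears on why methoxy stands apart from hydrogen here.

From the compounds shown here alone, whether an ethoxy group, an amine or a carboxylic acid on this carbon would carry the read-out further remains open. Also open, going by these compounds, is whether methoxy gives a similar step when the rest of the shared core is changed.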